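Replacing 4-methoxybenzyl with 3-methylphenyl: notes on compound 4

The compounds below may be only part of what the source reports. "The series", "measured", "known", "first", "only" and "open" are said of these compounds alone.

Measured in an ADME assay on L02 cells (Homo sapiens) for inhibition, read by CCK-8 assay, with a stated time of 48 h; a lower number here means a stronger inhibitor of growth, a higher number a weaker inhibitor of growth:
- compound 1 `CN1CCN(c2ccc(Nc3ncc(Cl)c(NCc4ccccc4)n3)nc2)CC1`: 20300 nM
- compound 2 `Cc1ccc(CNc2nc(Nc3ccc(N4CCN(C)CC4)cn3)ncc2Cl)cc1`: > 100000 nM (a limit of the assay)
- compound 3 `COc1ccc(CNc2nc(Nc3ccc(N4CCN(C)CC4)cn3)ncc2Cl)cc1`: 12900 nM

Compound 3 at 12900 nM lies within the scatter of compound 1. Compound 2 gives only a limit.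

Compound 4 `Cc1cccc(Nc2nc(Nc3ccc(N4CCN(C)CC4)cn3)ncc2Cl)c1` carries 3-methylphenyl in place of 4-methoxybenzyl on a nitrogen on an aromatic ring.

The measured steps are a 1.6-fold lower number from compound 1 to compound 3 (0.20 log units; within the scatter), an at least 4.9-fold higher number from compound 1 to compound 2 (0.69 log units; beyond the scatter) and an at least 7.7-fold lower number from compound 2 to compound 3 (0.88 log units; beyond the scatter). None of them makes this exchange, so they only suggest how widely this assay can move. The methyl step to compound 2 tilts the expectation slightly upward.

The expected change is a 1.6-fold higher number from compound 3 to compound 4 (0.19 log units; within the scatter).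

The estimated value for compound 4 is 20000 nM, with an expected range from 5000 nM to 90000 nM.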

Compound 4, concentration for 50% growth inhibition: 6080 nM
For compound 4 the middle estimate is 3.3-fold (0.52 log units) above the measured one; the measured number falls inside the stated range.
By their numbers in this assay, from the lowest: compound 4; then compounds 3 and 1 (each within the scatter of the next). At a limit, above all of these: compound 2.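

In this assay, 3-methylphenyl on this nitrogen gives a 2.1-fold lower number from compound 3 to compound 4 (0.33 log units; beyond the scatter) and a 3.3-fold lower number from compound 1 to compound 4 (0.52 log units; beyond the scatter), both beyond the scatter, so a directly attached aromatic ring is tolerated here and gives a lower number than 4-methoxybenzyl or benzyl. Against 4-methylbenzyl, the same exchange gives an at least 16-fold lower number from compound 2 to compound 4 (1.21 log units; beyond the scatter). Compound 2 gives only a limit of the assay, so that step is a bound and not a size: the limit of > 100000 nM in this assay, at which 1 of the 4 values shown sits.

The compounds shown do not separate the change from benzyl to phenyl from the effect of the methyl group and where it sits. Unsubstituted phenyl, 4-methylphenyl and a saturated group such as cyclohexyl on this nitrogen remain open.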